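The compounds below may be only part of what the source reports. "The series", "measured", "known", "first", "only" and "open" are said of these compounds alone.

Compound 1 `Nc1nc(-c2ccccc2)nc2c1nnn2Cc1ccccc1` carries a free amino group on its shared core. Among the compounds with values here, in an assay on CHO cells for displacement of a labelled ligand from adenosine receptor A3 (Homo sapiens), read by scintillation counting (a higher number here means a weaker inhibitor, a lower number a stronger inhibitor), compound 1 gives 4220 nM, the highest of the three numbers measured so far, though its nearest neighbour, compound 2, sits essentially at the same place and even the furthest, compound 3, remains within the scatter. Compound 2 `O=C(Nc1nc(-c2ccccc2)nc2c1nnn2Cc1ccccc1)c1ccc(C(F)(F)F)cc1` bears a 4-(trifluoromethyl)phenyl carbonyl on that amino nitrogen; in this assay compound 2 gives 4210 nM. Compound 3 `O=C(Nc1nc(-c2ccccc2)nc2c1nnn2Cc1ccccc1)c1cccc(C(F)(F)F)c1` carries the 3-(trifluoromethyl)phenyl carbonyl instead, and in this assay compound 3 gives 2510 nM. Within the data shown here, the one step measured between neighbours, a 1.7-fold lower number from compound 2 to compound 3 (0.22 log units; within the scatter), is too small to count as a real change.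

Compound 4 `O=C(Nc1nc(-c2ccccc2)nc2c1nnn2Cc1ccccc1)c1ccccc1F` is reached from compound 1 by (2-fluorophenyl)carbonyl in place of hydrogen on a nitrogen on an aromatic ring. Among the measured compounds shown here, no step from compound 1 to an acylated partner is directly computed, but the values of compound 1 and compound 2 show that attaching an aryl carbonyl of this kind left the number where it was, and moving the substituent around the ring hardly mattered either. The step of a 1.2-fold lower number from compound 1 to compound 4 (0.08 log units; within the scatter) is therefore expected to stay within the scatter. Compound 4 is estimated at 3500 nM, with a plausible range from 1500 nM to 9000 nM.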

Compound 4, inhibition constant: 5300 nM
Compound 4: middle estimate off by 1.5-fold (0.18 log units), on the low side, within the range that was stated.
By their numbers in this assay, from the lowest: compounds 3, 2, 1 and 4 (each within the scatter of the next, the first and the last beyond it).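

The acyl group adds nine heavy atoms to the nitrogen, yet in this assay the change from free amino to ((2-fluorophenyl)carbonyl)amino gives only a 1.3-fold higher number from compound 1 to compound 4 (0.10 log units; within the scatter), so this position tolerates a 2-fluorophenyl carbonyl as it does the 4-(trifluoromethyl)phenyl carbonyl of compound 2. Within the data shown here, exchanging one aryl group for another on the carbonyl carbon matters little here: a 1.3-fold higher number from compound 2 to compound 4 (0.10 log units; within the scatter) stays inside the scatter, while a 2.1-fold higher number from compound 3 to compound 4 (0.32 log units; beyond the scatter) is the first step to pass beyond it, and only modestly, so the aryl group can shift the number slightly but the effect depends on which pair is compared. No measurement here accounts for that small difference.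

All the acyl groups shown are substituted benzoyl groups, so it remains open whether an acetyl group, a longer alkyl chain or an aryl ring carrying a carboxylic acid or an amine on that nitrogen would move the number further. On these data alone, it also remains open whether any such group could bring the number well below those of compound 1 and its acylated partners.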